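Extending the Chain: Compound 1 to Compound 4

This account rests on a few compounds, and the source may have more. Where it says the series, first, only, none or still open, it means among the compounds named here.

Three compounds built on the same bicyclic core share a carboxylic acid and an amide, and differ only in what the amide nitrogen carries. Compound 1 `CCCCNC(=O)C1C(C(=O)O)[C@@H]2CC[C@H]1O2` bears a butyl group; compound 2 `CCc1ccccc1NC(=O)C1C(C(=O)O)[C@@H]2CC[C@H]1O2` and compound 3 `O=C(O)c1ccc(NC(=O)C2C(C(=O)O)[C@@H]3CC[C@H]2O3)cc1Cl` carry aromatic groups. In an ADME assay on HT-29 cells (Homo sapiens) for cytotoxicity, read by MTT assay, with a stated time of 72 h (a higher number here means a weaker inhibitor of growth, a lower number a stronger inhibitor of growth), compound 1 gives 10000 nM, compound 2 gives 10000 nM, and compound 3 gives 10000 nM, so compound 1 stands level with both. Compound 4 `CCCCCCCCNC(=O)C1C(C(=O)O)[C@@H]2CC[C@H]1O2` has not been measured; it differs from compound 1 by butyl in place of hydrogen on a saturated chain carbon, four bonds along the chain from an amide-type nitrogen. Among the measured compounds shown here, with the three measured compounds all at the same level, no step among them points in any direction. The step from compound 1 to compound 4 is therefore expected to be small, about no change at the digits printed from compound 1 to compound 4 (within the scatter). Compound 4 is expected to give about 10000 nM, within 3000 nM to 20000 nM.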

Compound 4, concentration for 50% growth inhibition: 10000 nM
For compound 4 middle estimate and measured number coincide at the digits printed, within the range that was stated.
By their numbers in this assay, from the lowest: compounds 1, 2, 3 and 4 (each within the scatter of the next).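

In this assay, butyl in place of hydrogen on a saturated chain carbon, four bonds along the chain from an amide-type nitrogen, gives no change at the digits printed from compound 1 to compound 4 (within the scatter). Among the compounds shown here, this is the first comparison of compounds that differ in one place, and it shows that lengthening the chain at this position by butyl leaves the two compounds level. Nothing measured here offers an explanation for this result. As far as these compounds go, whether an amine or a carboxylic acid on this chain, or a longer chain, would read differently remains open.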